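Swapping the Methoxyphenyl Group: Expectations for Compound 4

The source may report more compounds than this note shows. Statements on the series, on what has been measured and on what is new or still open speak of the compounds shown alone.

Of the compounds shown here, three of one series have been measured in an ADME assay on Vero cells (Chlorocebus sabaeus) for cytotoxicity, read by neutral red uptake, with a stated time of 72 h; a higher number here means a weaker inhibitor, a lower number a stronger inhibitor. Compound 1 `COc1ccc(Nc2ccnc(NCCCNc3ccnc4cc(Cl)ccc34)n2)cc1` gives 13300 nM. Compound 2 `COc1cc(Nc2ccnc(NCCCNc3ccnc4cc(Cl)ccc34)n2)cc(OC)c1` gives 12900 nM. Compound 3 `COc1ccc(Nc2ccnc(NCCCCNc3ccnc4cc(Cl)ccc34)n2)cc1` gives 11100 nM. The step from compound 1 to compound 2 is a 1.0-fold lower number from compound 1 to compound 2 (0.01 log units; within the scatter), and the change behind it is 3,5-dimethoxyphenyl in place of 4-methoxyphenyl on a nitrogen on an aromatic ring. Compound 1 and compound 3 differ in more than one place, so the difference between the two cores is not broken down here; their two values simply lie close together.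

Compound 4 `COc1cc(Nc2ccnc(NCCCCNc3ccnc4cc(Cl)ccc34)n2)cc(OC)c1` has not yet been measured. It arises from compound 3 by the same change, (3,5-dimethoxyphenyl in place of 4-methoxyphenyl on a nitrogen on an aromatic ring), and the surroundings of the place are the same in both pairs. Because the earlier step of a 1.0-fold lower number from compound 1 to compound 2 (0.01 log units; within the scatter) stayed within the scatter, the matching step is also expected to be small. For compound 4 the expected step is a 1.0-fold lower number from compound 3 to compound 4 (0.00 log units; within the scatter). Compound 4 is therefore estimated at 11000 nM in this assay, with a likely range from 5500 nM to 22000 nM.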

Compound 4, half-maximal inhibitory concentration: 12500 nM
Estimate against measurement, compound 4: 1.1-fold (0.06 log units) below, and the stated range covers the measured number.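

In this assay, putting 3,5-dimethoxyphenyl in place of 4-methoxyphenyl on the core of compound 3 gives a 1.1-fold higher number from compound 3 to compound 4 (0.05 log units; within the scatter), so this step is small, as the earlier one was. The change therefore behaves alike on the two cores shown: the same change on two cores in this assay, a 1.0-fold lower number (0.01 log units; within the scatter) from compound 1 to compound 2 and a 1.1-fold higher number (0.05 log units; within the scatter) from compound 3 to compound 4, 1.2-fold (0.06 log units) apart, within the scatter of two such steps. This supports carrying the change between these two cores in this assay, but two pairs cannot show that it would stay as small on any other core, and with both steps inside the usual scatter, they show no measurable effect of the change to carry across.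

Every group shown on this nitrogen is a methoxy-substituted phenyl, so it remains open what an unsubstituted phenyl, an amine or a carboxylic acid would do at this place, or a longer chain such as butoxy in place of methoxy. Going by these compounds, whether the change stays this small in any other assay also remains open, as these numbers speak only to this assay.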